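The compounds below may be only part of what the source reports. "The series", "measured", "known", "first", "only" and "open" are said of these compounds alone.

Compound 1 (`Cc1ccc(SCc2ccc(C(=O)Nc3ccccc3N)cc2)cc1`) gives 3700 nM in a functional assay on A-375 cells (Homo sapiens) for antiproliferative activity, read by CCK-8 assay, with a stated time of 72 h (on this read-out lower numbers stand for stronger inhibition and higher numbers for weaker inhibition), and compound 2 (`Nc1ccccc1NC(=O)c1ccc(CSCCc2ccccc2)cc1`) gives 2860 nM. Compound 3 (`Nc1ccccc1NC(=O)c1ccc(CSc2ccc(F)cc2)cc1`) offers no number as a starting point, its result being "not determined" (no result reported). Compound 4 (`Cc1cc(C)cc(SCc2ccc(C(=O)Nc3ccccc3N)cc2)c1`) carries 3,5-dimethylphenyl in place of 4-fluorophenyl on a sulfur. Going by the values given here, the only measured step, a 1.3-fold lower number from compound 1 to compound 2 (0.11 log units; within the scatter), puts phenethyl in place of 4-methylphenyl on a sulfur and stays within the scatter. Among the compounds with values here, with no value for compound 3, no step from it can be sized, so the expectation rests on the level of compound 1 at 3700 nM and compound 2 at 2860 nM in this assay. Compound 4 is estimated at 3300 nM, with an expected range of 1400 nM to 7500 nM.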

Compound 4, half-maximal inhibitory concentration: 3670 nM
The estimate for compound 4 lay 1.1-fold (0.05 log units) below the measured number; measured number inside the range.
By their numbers in this assay, from the lowest: compounds 2, 4 and 1 (each within the scatter of the next).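

In this assay, 3,5-dimethylphenyl on a sulfur reads level with the two other groups there, with a 1.3-fold higher number from compound 2 to compound 4 (0.11 log units; within the scatter) and a 1.0-fold lower number from compound 1 to compound 4 (0.00 log units; within the scatter) and both steps within the scatter, so this position has now taken three different carbon-only groups without a step beyond the scatter. Going by these compounds alone, no step from compound 3 can be read, so the change from 4-fluorophenyl itself remains unsized. Nothing measured here explains this flatness. As far as these compounds go, whether an amine or a carboxylic acid on this group would move the number beyond the scatter stays open. So does the effect of a longer chain on the sulfur.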